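This account rests on a few compounds, and the source may have more. Where it says the series, first, only, none or still open, it means among the compounds named here.

In a functional assay on cells (Homo sapiens) for antiproliferative activity, read by sulforhodamine B assay, with a stated time of 48 h (on this read-out lower numbers stand for stronger inhibition and higher numbers for weaker inhibition), compound 2 `CCCCCCCCCCCCNC(=O)[C@@H]1CSC(c2ccc(NC(C)=O)cc2)N1` gives 2400 nM. That is within the scatter of compound 1 `CCCCCCCCCCCCNC(=O)[C@@H]1CSC(c2ccc(OC)c(OC)c2)N1` at 2900 nM, and both sit well under compound 3 `CCCCCCCCCCCCCCCCCCNC(=O)[C@@H]1CSC(c2ccc(NC(C)=O)cc2)N1` at 22300 nM. Compound 4 `CCCCCCCCCCCCNC(=O)[C@@H]1CSC(c2ccc(N)cc2)N1` has hydrogen in place of acetyl on a nitrogen on an aromatic ring of compound 2: hydrogen in place of acetyl on a nitrogen on an aromatic ring. Among the measured compounds shown here, no measured step changes this group alone. The closest evidence is the swap of 3,4-dimethoxyphenyl for 4-acetamidophenyl, a 1.2-fold lower number from compound 1 to compound 2 (0.08 log units; within the scatter), which stayed within the scatter. The chain change, a 9.3-fold higher number from compound 2 to compound 3 (0.97 log units; beyond the scatter), was larger but lies elsewhere in the molecule. No shift beyond the scatter is therefore expected, and the estimated step is a 1.0-fold higher number from compound 2 to compound 4 (0.02 log units; within the scatter). For compound 4 the estimated value is 2500 nM, with an expected range from 1000 nM to 6500 nM.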

Compound 4, half-maximal inhibitory concentration: 2200 nM
Compound 4: the middle estimate sits 1.1-fold (0.06 log units) above what was measured; the measured number falls inside the stated range.
By their numbers in this assay, from the lowest: compounds 4, 2 and 1 (each within the scatter of the next); then compound 3.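

Taking the acetyl off the nitrogen on the aromatic ring tests this group alone for the first time, and in this assay the change gives a 1.1-fold lower number from compound 2 to compound 4 (0.04 log units; within the scatter) and stays within the scatter, so at this position the acetyl is not needed to keep the number at this level. The 4-aminophenyl compound also stays within the scatter of the 3,4-dimethoxyphenyl one, with a 1.3-fold lower number from compound 1 to compound 4 (0.12 log units; within the scatter) on the same shared core. Nothing available explains this lack of change.

Still open, going by these compounds, is whether a larger group on this nitrogen, such as benzoyl or methanesulfonyl, would shift the number beyond the scatter. The same question stands for a carboxylic acid in place of the amino group.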